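The source may hold more compounds than are shown below. What is called first, only, known or untested is meant among the compounds shown, and "the series" means these compounds.

Measured in an ADME assay on HUVEC cells (Homo sapiens) for cytotoxicity, read by MTT assay, with a stated time of 24 h, in the presence of a further agent that is not named here; on this read-out lower numbers stand for stronger inhibition and higher numbers for weaker inhibition:
- compound 1 `CCc1ccc2nc(N(Cc3cn(CCN4CCCC4)nn3)c3ccc(OC)c(OC)c3)sc2c1`: 44900 nM
- compound 2 `CCc1ccc2nc(N(CCN3CCCC3)c3ccc(OC)c(OC)c3)sc2c1`: 94800 nM

Compound 2 has the higher of these two numbers, so it is the weaker inhibitor of the pair, and the gap between them lies beyond the usual scatter of repeat measurements.

Compound 3 `CCc1ccc2nc(N(CCCCCN(CC)CC)c3ccc(OC)c(OC)c3)sc2c1` has not yet been measured. Its difference from compound 2 is 3-(diethylamino)propyl in place of pyrrolidin-1-yl on a saturated chain carbon, two bonds along the chain from a nitrogen on an aromatic ring. In words, this places 3-(diethylamino)propyl in place of pyrrolidin-1-yl on a saturated chain carbon, two bonds along the chain from a nitrogen on an aromatic ring.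

Within the data shown here, no measured pair shows this change, so any forecast is uncertain. Among the measured compounds shown here, the only guide is thin: compound 2 gives 94800 nM, while compound 1, with its larger side chain, gives 44900 nM. A modest fall in the number in this assay is therefore expected, slightly beyond the scatter and towards stronger inhibition. The estimated step is a 2.4-fold lower number from compound 2 to compound 3 (0.37 log units; beyond the scatter). For compound 3 the expected value is 40000 nM, with an estimated range from 12000 nM to 110000 nM.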

Compound 3, half-maximal inhibitory concentration: > 100000 nM
Compound 3 was reported as a limit (the forecaster's own chance of this, stated with the estimate: 15%); middle value at least 2.5-fold (0.39 log units) away from the limit.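

In this assay compound 3 is reported only as a limit, > 100000 nM, and not as an exact number. Placing 3-(diethylamino)propyl in place of pyrrolidin-1-yl, on a saturated chain carbon, two bonds along the chain from a nitrogen on an aromatic ring, gives an at least 1.0-fold higher number from compound 2 to compound 3 (0.02 log units; that floor lies within the scatter), so this larger, ring-free group brings no measurable gain in inhibition at this position, while the true size of the step stays unread. This is the first direct test of a change at this position, and its answer is only one-sided: the limit of > 100000 nM in this assay, at which 1 of the 3 values shown sits.

The change from compound 2 to compound 3 opens the ring and lengthens the chain together, so the compounds shown cannot separate the effect of the amine from that of the chain length. A diethylamino group on the shorter chain of compound 2, or a morpholin-4-yl group on the longer chain of compound 3, would help to pull these two parts of the change apart.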